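A few compounds are considered here, and "the series" means these few. Any claim that something is new, unique, unknown or untested is made for them only; others in the source may bear on it.

Measured compounds:
compound 1, `COc1cc2oc(-c3cccc(NC(=O)c4ccc(C(F)(F)F)cc4)c3)cc(=O)c2c(OC)c1OC`, "active" (no number reported) in a functional assay on UO-31 cells (Homo sapiens) for inhibition, read by sulforhodamine B assay, tested at 10 uM; on this read-out higher numbers stand for more inhibition at the one concentration tested (going by the name of the read-out) and lower numbers for less inhibition
compound 2, `COc1cc2oc(-c3cccc(NC(=O)c4ccccc4Br)c3)cc(=O)c2c(OC)c1OC`, "active" (no number reported) in this assay
compound 3, `COc1cc2oc(-c3cccc(NC(=O)c4ccc(Br)cc4)c3)cc(=O)c2c(OC)c1OC`, 63.6% in this assay

Three compounds sharing one core have been examined in this assay. For compound 1 and compound 2 the assay records only that each is active, without a number, so the single figure that can be placed on a scale is that of compound 3, which in this assay gives 63.6%. Within the data shown here, compound 3 therefore stands alone as the one numerically characterised member of the set; no ordering against compound 1 or compound 2 can be drawn.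

The next compound, compound 4, `COc1cc2oc(-c3cccc(NC(=O)c4cccc(C#N)c4)c3)cc(=O)c2c(OC)c1OC`, differs from compound 3 in a single place: 3-cyanophenyl in place of 4-bromophenyl on a carbonyl carbon. Among the measured compounds shown here, no step between two measured compounds is available here, so there is no measured precedent for what an exchange at the carbonyl carbon does in this assay. The expected step from compound 3 to compound 4 in this assay is estimated at a number 8.6 percentage points lower from compound 3 to compound 4 (within the scatter), a modest drop that may well stay within the usual scatter. On that basis compound 4 is expected to give about 55% in this assay, with a likely range from 30% to 75%.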

Compound 4, a percentage reported as inhibition, at one concentration (the size of the read-out at that concentration, not a potency): "active" (no number reported)
The entry for compound 4 holds no number; the estimate stays without a comparison.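

In this assay compound 4 is recorded as "active" (no number reported), so no step can be read between compound 3, at 63.6%, and compound 4. Nothing further at hand bears on this result. The compounds shown leave open how 3-cyanophenyl and 4-bromophenyl compare on the carbonyl carbon, and where compound 1, compound 2 and compound 4 stand on the percentage scale.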